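The source may hold more compounds than are shown below. What is called first, only, known or untested is meant among the compounds shown, and "the series" means these compounds.

Measured compounds:
compound 1, `COc1ccc(-c2cc(/C=C/C(=O)c3ccc(N)cc3)[nH]n2)cc1`: 11600 nM
compound 2, `COc1ccc(C(=O)/C=C/c2cc(-c3cc(OC)c(OC)c(OC)c3)n[nH]2)cc1OC`: 7120 nM
compound 3, `COc1ccc(-c2cc(/C=C/C(=O)c3ccc(N)cc3)[nH]n2)cc1OC`: 36400 nM

All three were tested in a functional assay on K562 cells (Homo sapiens) for inhibition, read by sulforhodamine B assay, with a stated time of 48 h; on this read-out higher numbers stand for weaker inhibition of growth and lower numbers for stronger inhibition of growth. Compound 1 gives 11600 nM. Compound 3 differs from it by methoxy in place of hydrogen on an aromatic carbon and gives 36400 nM; the step is a 3.1-fold higher number from compound 1 to compound 3 (0.50 log units; beyond the scatter). Compound 2 gives 7120 nM. The difference between the core of compound 2 and the core of compound 1 is not broken down here; the numbers of compound 1 and compound 2 lie within the scatter of each other, so no order between them can be read. Compound 3 stands beyond the scatter from compound 2.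

Compound 4, `COc1cc(C(=O)/C=C/c2cc(-c3cc(OC)c(OC)c(OC)c3)n[nH]2)cc(OC)c1OC`, has not yet been measured in this assay. It differs from compound 2 by methoxy in place of hydrogen on an aromatic carbon. This is the same kind of change as from compound 1 to compound 3, but the surroundings are not identical: in compound 4 the entering methoxy is also meta to a methoxy group, which is not so in compound 3. Among the measured compounds shown here, only one measured example of this kind of step exists, so the expectation rests on it alone. For the measured compounds named here, the step from compound 2 to compound 4 is expected to be a 2.1-fold higher number from compound 2 to compound 4 (0.32 log units; beyond the scatter), of roughly the size seen before, with wide uncertainty because a 3.1-fold higher number from compound 1 to compound 3 (0.50 log units; beyond the scatter) is the only guide. Compound 4 is thus estimated at 15000 nM, most likely between 6000 nM and 40000 nM.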

Compound 4, concentration for total growth inhibition: > 100000 nM
Compound 4: a limit, no number; the forecaster's own chance of this, stated with the estimate: 5%; middle value at least 6.6-fold (0.82 log units) from the limit.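

In this assay, among the compounds shown here, compound 4 gives > 100000 nM, which is a limit of the assay and not a number, and it is the only value of its kind here: the limit of > 100000 nM in this assay, at which 1 of the 4 values shown sits. On the core of compound 2, methoxy in place of hydrogen on an aromatic carbon gives an at least 14-fold higher number from compound 2 to compound 4 (1.14 log units; beyond the scatter), so the change moves the number in the same direction on both cores, but its size does not carry over from one core to the other: the same change on two cores in this assay, a 3.1-fold higher number (0.50 log units; beyond the scatter) from compound 1 to compound 3 and an at least 14-fold higher number (1.14 log units; beyond the scatter) from compound 2 to compound 4, at least 4.4-fold (0.65 log units) apart, beyond the scatter of two such steps. For the compounds shown here, with only two pairs, this does not show whether the gap between the steps goes with the core as a whole or with the surroundings of the entering methoxy, which in compound 4 is meta to a methoxy group, and the limit means that the full size of the second step stays unknown.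

The compounds shown leave open what a hydroxy group, a fluorine atom or an ethoxy group in place of that hydrogen would do on either core. They also leave open whether the same change would follow either of these two steps on a further core, such as one carrying a carboxylic acid.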